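Urea arm replaced by a benzamide in the shared core

The source may hold more compounds than are shown below. What is called first, only, known or untested is meant among the compounds shown, and "the series" means these compounds.

Three compounds on the shared core have been run in a functional assay on DU-145 cells (Homo sapiens) for inhibition, read by sulforhodamine B assay, with a stated time of 48 h, tested at 10 uM; on this read-out lower numbers stand for a stronger effect and higher numbers for a weaker effect at the one concentration tested. Compound 1 `COc1cc(Cl)cc(-c2nn(-c3cccc(NC(=O)Nc4ccc(Cl)c(C(F)(F)F)c4)c3)cc2-c2ccncc2)c1` gives 15.2%, compound 2 `COc1cc(Cl)cc(-c2nn(-c3cccc(NC(=O)Nc4ccc(Cl)c(Cl)c4)c3)cc2-c2ccncc2)c1` gives 12.1%, and compound 3 `COc1cc(Cl)cc(-c2nn(-c3cccc(NC(=O)Nc4cccc(C(F)(F)F)c4)c3)cc2-c2ccncc2)c1` gives 15.9%. The three numbers sit close together: the step of a number 3.1 percentage points lower from compound 1 to compound 2 (within the scatter) and the step of a number 0.7 percentage points higher from compound 1 to compound 3 (within the scatter) are both within the scatter, as is the step of a number 3.8 percentage points higher from compound 2 to compound 3 (within the scatter). Compound 3 therefore holds the nominally top number of the three, but nothing separates it from compound 1 or compound 2 beyond the noise of the measurement.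

Compound 4 `COc1cc(Cl)cc(-c2nn(-c3cccc(NC(=O)c4cccc(C(F)(F)F)c4)c3)cc2-c2ccncc2)c1` changes something the measured steps never touched: 3-(trifluoromethyl)phenyl in place of (3-(trifluoromethyl)phenyl)amino on a carbonyl carbon. Among the measured compounds shown here, every step so far swapped substituents on the outer aromatic ring of the urea, chloro for trifluoromethyl or hydrogen for chloro, and each stayed within the scatter. For the measured compounds named here, none altered the carbonyl carbon whose other neighbour is an amide-type nitrogen, so no measured step bears directly on the loss of one hydrogen-bond donor. With the series this flat across three variations, the step of a number 0.1 percentage points higher from compound 3 to compound 4 (within the scatter) is expected to be no larger than the scatter, in either direction. Compound 4 is accordingly estimated at 16%, within a range of 4% to 30% in this assay.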

Compound 4, a percentage reported as activity, at one concentration (the size of the read-out at that concentration, not a potency): 83.8%
Estimate against measurement, compound 4: 67.8 percentage points below; the measured number lies above the stated range.
By their numbers in this assay, from the lowest: compounds 2, 1 and 3 (each within the scatter of the next); then compound 4.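

In this assay, the carbonyl carbon whose other neighbour is an amide-type nitrogen emerges as far less tolerant of change than the outer aromatic ring: 3-(trifluoromethyl)phenyl in place of (3-(trifluoromethyl)phenyl)amino gives a number 67.9 percentage points higher from compound 3 to compound 4 (beyond the scatter), a weaker effect at the one concentration tested, whereas the substituent swaps on the outer ring all stayed within the scatter. The large step appears from each of the other two ureas as well, as a number 71.7 percentage points higher from compound 2 to compound 4 (beyond the scatter) and a number 68.6 percentage points higher from compound 1 to compound 4 (beyond the scatter), so among these compounds it does not depend on which outer ring the urea carries. No available evidence accounts for the size of this step.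

The single benzamide leaves open whether the amino nitrogen itself is decisive, and a carbamate oxygen, a methylene group or a methylated urea nitrogen at this place would help separate that question from the change in the linking chain. Going by these compounds, it also remains open whether a benzamide carrying 3,4-dichlorophenyl or 4-chloro-3-(trifluoromethyl)phenyl would read like compound 4 in this assay.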